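This account rests on a few compounds, and the source may have more. Where it says the series, first, only, none or still open, it means among the compounds named here.

Measured so far in a functional assay on HT-29 cells (Homo sapiens) for inhibition, read by MTT assay, with a stated time of 72 h; on this read-out higher numbers stand for weaker inhibition and lower numbers for stronger inhibition:
compound 1 `C=C(Br)C(=O)Nc1cccc(/C=C/C(=O)Nc2ccc(F)cc2)c1` gives 36600 nM
compound 2 `C=C(Br)C(=O)Nc1cccc(/C=C/C(=O)Nc2ccc(F)c(F)c2)c1` gives 8700 nM
compound 3 `C=C(Br)C(=O)Nc1cccc(/C=C/C(=O)NCc2ccc(C)cc2)c1` gives 2700 nM

Compound 1 stands highest of the three, so it is the weakest inhibitor here. Compound 4 `C=C(Br)C(=O)Nc1cccc(/C=C/C(=O)Nc2ccc(OC(F)(F)F)cc2)c1` differs from it by trifluoromethoxy in place of fluoro on an aromatic carbon. Among the compounds with values here, no measured step makes this exact change. Closest is fluoro in place of hydrogen on an aromatic carbon, with a 4.2-fold lower number from compound 1 to compound 2 (0.62 log units; beyond the scatter) as a modest step. The large 14-fold lower number from compound 1 to compound 3 (1.13 log units; beyond the scatter) exchanges the whole 4-fluorophenyl for 4-methylbenzyl and bears less directly. Going by a 4.2-fold lower number from compound 1 to compound 2 (0.62 log units; beyond the scatter) again, a modest step to a lower number is expected in this assay here. The estimate means a 3.1-fold lower number from compound 1 to compound 4 (0.48 log units; beyond the scatter) as the expected step. Compound 4 is expected at 12000 nM (estimated range 4000 nM to 36000 nM).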

Compound 4, half-maximal inhibitory concentration: 61200 nM
Compound 4: the middle estimate sits 5.1-fold (0.71 log units) below what was measured; the measured number lies above the stated range.
By their numbers in this assay, from the lowest: compound 3; then compound 2; then compounds 1 and 4 (each within the scatter of the next).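

In this assay, trifluoromethoxy in place of fluoro on an aromatic carbon, para to a large group, gives a 1.7-fold higher number from compound 1 to compound 4 (0.22 log units; within the scatter). The earlier compounds shown here showed a clear step when a second fluoro was added, a 4.2-fold lower number from compound 1 to compound 2 (0.62 log units; beyond the scatter), whereas this exchange of the fluoro itself, for a group of 5 heavy atoms, leaves the two compounds indistinguishable. No measurement at hand explains this result. Going by these compounds, whether an amine or a methoxy group at this position would also stay within the scatter of compound 1 remains open.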